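Three Triazolyl Ureas and the Next Aryl Swap

This account rests on a few compounds, and the source may have more. Where it says the series, first, only, none or still open, it means among the compounds named here.

In a functional assay on A549 cells (Homo sapiens) for cytotoxicity, read by MTT assay, with a stated time of 48 h (on this read-out higher numbers stand for weaker inhibition and lower numbers for stronger inhibition), compound 3 `COc1ccc(CN(C(=O)Nc2ccc(F)c(Cl)c2)n2cnnc2)cc1OC` gives 21000 nM, the lowest of the three numbers, though the other two stand within the scatter of it. Compound 1 `COc1cc(CN(C(=O)Nc2ccc(C)cc2)n2cnnc2)cc(OC)c1OC` gives 22800 nM in this assay, and compound 2 `CCc1ccc(NC(=O)N(Cc2ccc(OC)c(OC)c2)n2cnnc2)cc1` gives 28400 nM. Among the measured compounds shown here, the one step that can be read directly, a 1.4-fold lower number from compound 2 to compound 3 (0.13 log units; within the scatter), stays within the scatter, so the aryl group on the amide-type nitrogen has so far not moved the number in a way that can be trusted.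

Compound 4 `COc1ccc(CN(C(=O)Nc2ccc(C)cc2)n2cnnc2)cc1OC` is obtained from compound 3 by the change (4-methylphenyl in place of 3-chloro-4-fluorophenyl on an amide-type nitrogen). Compound 1 already carries the 4-methylphenyl group on a related core and compound 2 carries 4-ethylphenyl, and both of their values sit close to that of compound 3. The expected step of a 1.1-fold higher number from compound 3 to compound 4 (0.06 log units; within the scatter) is therefore no larger than the scatter, in no fixed direction. For compound 4 the estimated value in this assay is 24000 nM, within a range from 12000 nM to 48000 nM.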

Compound 4, half-maximal inhibitory concentration: 22200 nM
For compound 4 the middle estimate is 1.1-fold (0.03 log units) above the measured one, within the range that was stated.
By their numbers in this assay, from the lowest: compounds 3, 4, 1 and 2 (each within the scatter of the next).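

In this assay the change on the amide-type nitrogen can now be read on one shared core, and a 1.1-fold higher number from compound 3 to compound 4 (0.02 log units; within the scatter) stays within the scatter, so 4-methylphenyl and 3-chloro-4-fluorophenyl are not told apart at this position. The two neighbouring changes read the same way: hydrogen in place of methyl on the saturated chain carbon gives a 1.3-fold lower number from compound 2 to compound 4 (0.11 log units; within the scatter) and hydrogen in place of methoxy on an aromatic carbon gives a 1.0-fold lower number from compound 1 to compound 4 (0.01 log units; within the scatter), both within the scatter. No measurement is available that could explain this flat picture.

From the compounds shown here alone, it remains open whether a carboxylic acid or an amine on the aryl ring, or a longer chain in place of methyl, would give a step beyond the scatter. Also open, going by these compounds, is whether a hydroxy group in place of methoxy on the other aromatic ring would do so.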